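This account rests on a few compounds, and the source may have more. Where it says the series, first, only, none or still open, it means among the compounds named here.

Measured compounds in the series:

compound 1 `CCn1c([C@@H](C)NS(=O)(=O)c2ccc(Cl)cc2)nc2ccc(S(C)(=O)=O)cc21` — < 5 mL.min-1.g-1
compound 2 `CCn1c(C(C)NS(=O)(=O)c2ccc(Cl)cc2)nc2ncccc21` — 15 mL.min-1.g-1
compound 3 `CCn1c([C@@H](C)NS(=O)(=O)c2ccc(F)cc2)nc2ccc(C(F)(F)F)cc21` — 26 mL.min-1.g-1

In an ADME assay (liver) for metabolic stability, with Liver microsome (Homo sapiens) as the target, read by LC-MS, using microsomes and NADPH, with a stated time of 5 min, at 37 degrees C (on this read-out lower numbers stand for slow clearance and higher numbers for fast clearance), compound 3 gives 26 mL.min-1.g-1, the higher of the two numbers shown. Compound 2 at 15 mL.min-1.g-1 sits within the scatter of compound 3, so no order between the two can be read. For the measured compounds named here, the value of compound 1, < 5 mL.min-1.g-1, is a limit of the assay and not a number; it is the one value sitting at the limit of < 5 mL.min-1.g-1 in this assay, at which 1 of the 3 values shown sits. Going by the values given here, no pair of measured compounds differs in a single place, so no measured step is available in this assay.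

The next compound, compound 4 `CCn1ncc(S(=O)(=O)N[C@H](C)c2nc3ccc(C(F)(F)F)cc3n2CC)c1C`, differs from compound 3 in one place: 1-ethyl-5-methyl-1H-pyrazol-4-yl in place of 4-fluorophenyl on a sulfonyl sulfur. Among the compounds with values here, with no comparable step among the measured compounds, the expected change in this assay is none beyond the scatter, with no direction favoured. Compound 4 is therefore expected to give 22 mL.min-1.g-1, with a plausible range from 8 mL.min-1.g-1 to 55 mL.min-1.g-1, and the step of a 1.2-fold lower number from compound 3 to compound 4 (0.07 log units; within the scatter) is estimated to stay within the scatter of compound 3.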

Compound 4, intrinsic clearance in microsomes: > 100 mL.min-1.g-1
Compound 4: no number, only a limit (the forecaster's own chance of this, stated with the estimate: 10%); middle value at least 4.5-fold (0.65 log units) from the limit.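

For the compounds shown here, the sulfonyl sulfur, whose other neighbour is the sulfonamide nitrogen, is the first place where a single change can be read in this assay: 1-ethyl-5-methyl-1H-pyrazol-4-yl in place of 4-fluorophenyl gives an at least 3.8-fold higher number from compound 3 to compound 4 (0.58 log units; beyond the scatter). This position is therefore not neutral in this read-out: with the rest of compound 3 held fixed, exchanging this one group moves the number upward, beyond the scatter. The value of compound 4 is a limit of the assay and not a number: the limit of > 100 mL.min-1.g-1 in this assay, at which 1 of the 4 values shown sits.

As far as these compounds go, it remains open whether the rise comes from the ethyl and methyl groups on the entering ring or from the five-membered aromatic ring itself, a question that a 1H-pyrazol-4-yl without those two chains on the sulfonyl sulfur would address. Going by these compounds alone, it is also open whether the same exchange acts alike on the core of compound 1, and compounds 1, 2 and 3 differ from one another in more than one place, so no step among them can be read.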